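Three aryl groups and one untested iodo swap

A few compounds are considered here, and "the series" means these few. Any claim that something is new, unique, unknown or untested is made for them only; others in the source may bear on it.

Results in a functional assay on NCI-H322 cells (Homo sapiens) for cytotoxicity, read by MTT assay, with a stated time of 24 h (on this read-out higher numbers stand for weaker inhibition and lower numbers for stronger inhibition), for the three compounds examined so far:
Compound 1 `COc1ccc(/C=C\C(=O)O)c(OCc2cn(-c3ccc(NC(=O)c4ccccc4)cc3)nn2)c1CC=C(C)C` gives 17200 nM
Compound 2 `COc1cccc(-n2cc(COc3c(/C=C\C(=O)O)ccc(OC)c3CC=C(C)C)nn2)c1` gives 25200 nM
Compound 3 `COc1ccc(-n2cc(COc3c(/C=C\C(=O)O)ccc(OC)c3CC=C(C)C)nn2)cc1` gives "not determined" (no result reported)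

In this assay compound 2 gives 25200 nM and compound 1 gives 17200 nM on the same read-out. These two values lie within the usual scatter of each other, so neither compound can be ranked over the other. Compound 3 offers no number for comparison.

Compound 4 `COc1ccc(/C=C\C(=O)O)c(OCc2cn(-c3ccccc3I)nn2)c1CC=C(C)C` has not yet been measured. It differs from compound 2 in one place, with 2-iodophenyl in place of 3-methoxyphenyl on an aromatic nitrogen of a five-membered aromatic ring with 3 nitrogen (2-iodophenyl in place of 3-methoxyphenyl on an aromatic nitrogen). Going by the values given here, no measured pair isolates a change of this kind, and no measured compound carries iodine. Among the compounds with values here, the only guide is thin: compound 1 at 17200 nM and compound 2 at 25200 nM carry different groups on that nitrogen yet remain within the scatter. No step beyond the scatter is therefore expected, in either direction. The estimated step is a 1.3-fold lower number from compound 2 to compound 4 (0.10 log units; within the scatter) and is expected to stay within the scatter. In this assay the estimate for compound 4 is 20000 nM with an expected range from 9000 nM to 45000 nM until a measurement is available.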

Compound 4, half-maximal inhibitory concentration: 42300 nM
Compound 4: the middle estimate sits 2.1-fold (0.33 log units) below what was measured, within the range that was stated.
By their numbers in this assay, from the lowest: compounds 1, 2 and 4 (each within the scatter of the next, the first and the last beyond it).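

In this assay, replacing 3-methoxyphenyl with 2-iodophenyl on an aromatic nitrogen of the five-membered ring gives a 1.7-fold higher number from compound 2 to compound 4 (0.22 log units; within the scatter) and so does not allow the two compounds to be ranked. This gives the account its first readable step at this position: a ring with a methoxy group and one hydrogen-bond acceptor gives way to a ring with iodine and no hydrogen-bond acceptor, and the read-out shows no change beyond the usual scatter. No measurement is available that would explain this result, or show whether the same would hold in another setting.

The single step changes both the atom carried on the phenyl ring and the position named for it, so the compounds shown cannot say whether either change would matter without the other. They also leave open how an unsubstituted phenyl, or a phenyl bearing an amine or a carboxylic acid, would read on that nitrogen, and whether any such group would give a step beyond the scatter.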